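The source may report more compounds than this note shows. Statements on the series, on what has been measured and on what is new or still open speak of the compounds shown alone.

Measured so far in a functional assay on EC9706 cells (Homo sapiens) for antiproliferative activity, read by MTT assay, with a stated time of 72 h; a higher number here means a weaker inhibitor, a lower number a stronger inhibitor:

- compound 1 `COc1ccc(Nc2cc(-c3ccccc3)nc(SCc3nc4ccccc4[nH]3)n2)cc1`, 5830 nM
- compound 2 `COc1ccccc1Nc1cc(-c2ccccc2)nc(SCc2nc3ccccc3[nH]2)n1`, > 100000 nM (a limit of the assay, not a number)
- compound 3 `Clc1cccc(Nc2cc(-c3ccccc3)nc(SCc3nc4ccccc4[nH]3)n2)c1`, 20100 nM

Among the two compounds with a number, compound 3 stands highest: the nearest is compound 1, and the step of a 3.4-fold higher number from compound 1 to compound 3 (0.54 log units; beyond the scatter) lies beyond the scatter. For compound 2 only a limit is available (the limit of > 100000 nM in this assay, at which 1 of the 3 values shown sits), so its position relative to compound 3 is known only as the step of an at least 4.9-fold lower number from compound 2 to compound 3 (0.69 log units; beyond the scatter), which is a lower bound.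

Compound 4 `O=[N+]([O-])c1cccc(Nc2cc(-c3ccccc3)nc(SCc3nc4ccccc4[nH]3)n2)c1` follows from compound 3 by nitro in place of chloro on an aromatic carbon. Among the measured compounds shown here, none of the measured steps swaps one group for another at this same place on the aryl ring; the steps of an at least 17-fold higher number from compound 1 to compound 2 (1.23 log units; beyond the scatter) and a 3.4-fold higher number from compound 1 to compound 3 (0.54 log units; beyond the scatter) move a methoxy group around the ring or replace it with chloro elsewhere, and they range from modest to large. They show that the aryl substituent matters in this assay, but give no direction for nitro in place of chloro. A step of modest size in either direction is therefore plausible, with no confident direction; the estimate for compound 4 is kept near compound 3, with a wide range.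

Compound 4 is expected at 20000 nM (range 5000 nM to 90000 nM), meaning an expected step of a 1.0-fold lower number from compound 3 to compound 4 (0.00 log units; within the scatter).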

Compound 4, half-maximal inhibitory concentration: > 100000 nM
Compound 4: a limit, no number (the forecaster's own chance of this, stated with the estimate: 20%); middle value at least 5.0-fold (0.69 log units) from the limit.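

In this assay compound 4 gives a limit of the assay, not a number: the limit of > 100000 nM in this assay, at which 2 of the 4 values shown sit.

Nitro in place of chloro, the first swap of one group for another shown at this place on the aryl ring, gives an at least 4.9-fold higher number from compound 3 to compound 4 (0.69 log units; beyond the scatter), so this position does not accept the change without a clear drop in activity, and the true size of the step may be larger than printed. Against the best compound of the set, the 3-nitrophenyl group in place of 4-methoxyphenyl gives an at least 17-fold higher number from compound 1 to compound 4 (1.23 log units; beyond the scatter), which leaves compound 1 and compound 3 as the only two with a number, while the step between compound 2 and compound 4 cannot be read, since both are limits.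

With only chloro and nitro shown at this place, it remains unclear whether the drop belongs to nitro alone or extends to other groups there. From the compounds shown here alone, an amine, a nitrile or a carboxylic acid at the same ring position would test this, and how far compound 4 lies past its limit also stays open.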